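This account rests on a few compounds, and the source may have more. Where it says the series, first, only, none or still open, it means among the compounds named here.

Compound 1 `Nc1ccccc1NC(=O)c1ccc(COc2ccc([N+](=O)[O-])cc2)cc1`: > 32000 nM (a limit)
Compound 2 `Nc1ccccc1NC(=O)/C=C/c1ccc(COc2ccccc2)cc1`: > 32000 nM (a limit)
Compound 3 `CCc1ccc(OCc2ccc(C(=O)Nc3ccccc3N)cc2)cc1`: 6420 nM

For the measured compounds named here, in a functional assay on A549 cells (Homo sapiens) for antiproliferative activity, read by CCK-8 assay, with a stated time of 72 h (a lower number here means a stronger inhibitor, a higher number a weaker inhibitor), compound 3 gives 6420 nM, the only exact number in the set. The others reach no further than the limit of > 32000 nM in this assay, at which 2 of the 3 values shown sit.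

Compound 4 `Nc1ccccc1NC(=O)c1ccc(COc2ccc(F)cc2)cc1` has fluoro in place of ethyl on an aromatic carbon, para to a large group: fluoro in place of ethyl on an aromatic carbon. Going by the values given here, one measured step bears on this change, an at least 4.9-fold lower number from compound 1 to compound 3 (0.69 log units; beyond the scatter), where ethyl replaced nitro and the number fell beyond the scatter. Fluoro itself is untested, so removing the ethyl is expected to give back part of that gain, with a modest move towards a higher number. The expected step is a 1.9-fold higher number from compound 3 to compound 4 (0.27 log units; within the scatter). For compound 4 the estimated value is 12000 nM, with an expected range of 4500 nM to 32000 nM.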

Compound 4, half-maximal inhibitory concentration: 5370 nM
Estimate against measurement, compound 4: 2.2-fold (0.35 log units) above, and the stated range covers the measured number.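

Placing fluoro instead of ethyl on this aromatic carbon, para to a large group, leaves the antiproliferative reading in this assay within the scatter, with a 1.2-fold lower number from compound 3 to compound 4 (0.08 log units; within the scatter). The advantage over nitro therefore does not belong to ethyl alone, since fluoro also gives an at least 5.9-fold lower number from compound 1 to compound 4 (0.77 log units; beyond the scatter). The value of compound 1 is a limit, not an exact number: the limit of > 32000 nM in this assay, at which 2 of the 4 values shown sit.

Going by these compounds, what a methoxy group, an amine or a carboxylic acid would give at this position remains open. So does whether the ethyl and fluoro results carry over to the core of compound 2.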